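The compounds below may be only part of what the source reports. "The series", "measured", "known", "first", "only" and "open" are said of these compounds alone.

Measured compounds:
- compound 1 `CCC(=O)Nc1cccc(Oc2nc(Nc3ccc(N4CCC(OC)CC4)cc3OC)ncc2Cl)c1` gives 5.08% in an assay on isolated protein for inhibition of NUAK family SNF1-like kinase 1 (Homo sapiens), read by ADP-Glo, with a stated time of 60 min, tested at 10 uM, in the presence of a further agent that is not named here; a lower number here means less inhibition, a higher number more inhibition at the concentration tested (going by the name of the read-out)
- compound 2 `CCC(=O)Nc1cccc(Oc2nc(Nc3ccc(N4CCCCC4)cc3)ncc2Cl)c1` gives 86% in this assay
- compound 3 `CCC(=O)Nc1cccc(Oc2nc(Nc3ccc(N4CCC(C)CC4)cc3OC)ncc2Cl)c1` gives 9.2% in this assay

Compound 3 stands second highest of the three numbers in this assay. Its nearest neighbour is compound 1, and the step of a number 4.1 percentage points higher from compound 1 to compound 3 (within the scatter) is within the scatter, so the two cannot be told apart. Going by the values given here, compound 2 is far higher, but it differs from compound 3 in more than one place, so no single step can be drawn from it.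

Compound 4 `CCC(=O)Nc1cccc(Oc2nc(Nc3ccc(N4CCCCC4)cc3OC)ncc2Cl)c1` is reached from compound 3 by one change: hydrogen in place of methyl on a saturated ring carbon. Among the compounds with values here, the only measured step at the same ring carbon, a number 4.1 percentage points higher from compound 1 to compound 3 (within the scatter), was within the scatter, which suggests that what sits on this saturated ring carbon has little weight on its own. Compound 2 carries the unsubstituted piperidin-1-yl that compound 4 will have and gives a high number, yet it also lacks the methoxy group that compounds 1, 3 and 4 share, so its value cannot be cleanly credited to the piperidine change.

Compound 4 is therefore expected to give 18% in this assay, within a range of 3% to 55%, a step of a number 8.8 percentage points higher from compound 3 to compound 4 (within the scatter) that is expected to stay close to the scatter.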

Compound 4, a percentage reported as inhibition, at one concentration (the size of the read-out at that concentration, not a potency): 13.9%
Estimate against measurement, compound 4: 4.1 percentage points above; the range from low to high includes it.
By their numbers in this assay, from the lowest: compounds 1, 3 and 4 (each within the scatter of the next); then compound 2.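

Hydrogen, methyl and methoxy on this saturated ring carbon cannot be told apart in this assay: the step of a number 4.7 percentage points higher from compound 3 to compound 4 (within the scatter) joins the step of a number 8.8 percentage points higher from compound 1 to compound 4 (within the scatter) in staying within the scatter, so this position now has three groups behind that reading rather than two. Going by these compounds alone, the step of a number 72.1 percentage points lower from compound 2 to compound 4 (beyond the scatter) is the first comparison in which the high number of compound 2 is separated from the rest of the structure by one change, and it ties that large difference to methoxy in place of hydrogen on an aromatic carbon, not to the piperidine. Nothing measured here gives a reason for either result.

As far as these compounds go, it remains open whether a different group on that same aromatic carbon, such as fluorine or a longer ethoxy chain, would give a number as low as the methoxy does, or whether only hydrogen allows a high one. From the compounds shown here alone, it is also open whether an amine or a carboxylic acid on the saturated ring carbon would matter where methyl and methoxy could not be told from hydrogen, particularly on the high-scoring structure of compound 2 that has no aromatic methoxy.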